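Two chloro groups versus one: cytotoxicity in glioma cells

The compounds below may be only part of what the source reports. "The series", "measured", "known", "first", "only" and "open" are said of these compounds alone.

Measured compounds and their values in a functional assay on SNB-19 cells (Homo sapiens) for cytotoxicity, read by sulforhodamine B assay, with a stated time of 48 h; on this read-out higher numbers stand for lower toxicity in this test and lower numbers for higher toxicity in this test:
- compound 1 `ClCc1ccc(Cn2cnc3c(Cl)ncnc32)cc1` gives 89100 nM
- compound 2 `ClCc1ccc(Cn2cnc3nc(Cl)nc(Cl)c32)cc1` gives > 100000 nM, which is a limit of this assay and not a number
- compound 3 `ClCc1ccc(Cn2cnc3c(Cl)nc(Cl)nc32)cc1` gives > 100000 nM, again a limit and not a number

Compound 3 carries two chloro groups on its core; compound 1 keeps one. The change is hydrogen in place of chloro on an aromatic carbon, and the step is an at least 1.1-fold lower number from compound 3 to compound 1 (0.05 log units; that floor lies within the scatter). Its true size is open, because the limit of > 100000 nM in this assay, at which 2 of the 3 values shown sit, sits at the edge of what this assay can report. The two values of compound 1 and compound 3 are therefore not far apart, and no order between them can be claimed.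

Compound 2 has the same atoms as compound 3, joined differently; the difference between the two cores is not broken down here. Compound 4 `ClCc1ccc(Cn2cnc3ncnc(Cl)c32)cc1` has not yet been measured in this assay. It differs from compound 2 by hydrogen in place of chloro on an aromatic carbon, and the two place lines read the same word for word, so it is the same kind of change as that from compound 3 to compound 1.

Resting on compound 3 and compound 1 and on an at least 1.1-fold lower number from compound 3 to compound 1 (0.05 log units; that floor lies within the scatter), the step from compound 2 to compound 4 is expected to be an at least 1.0-fold lower number from compound 2 to compound 4 (0.02 log units; that floor lies within the scatter). Compound 4 is accordingly expected to give about 95000 nM, most likely between 45000 nM and 200000 nM, with a fair chance that this assay again reports only a limit.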

Compound 4, concentration lethal to 50% of the cells: 5750 nM
For compound 4 the middle estimate is 17-fold (1.22 log units) above the measured one; the measured number lies below the stated range.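

Hydrogen in place of chloro on an aromatic carbon, between two ring nitrogen atoms, can be a large step in this assay: an at least 17-fold lower number from compound 2 to compound 4 (1.24 log units; beyond the scatter). This shows that the change can matter a great deal in this series, but it does not show that the change acts differently on the two cores, because both steps are only floors: the same change on two cores in this assay, an at least 1.1-fold lower number (0.05 log units; that floor lies within the scatter) from compound 3 to compound 1 and an at least 17-fold lower number (1.24 log units; beyond the scatter) from compound 2 to compound 4; the limit leaves it open whether they differ. As far as these compounds go, the true size of each step also stays unknown, because each one starts from a limit and not from a number: the limit of > 100000 nM in this assay, at which 2 of the 4 values shown sit.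

From the compounds shown here alone, only chloro and hydrogen appear on these ring carbons, so it remains open whether an amine or a methoxy group there would give a value closer to that of compound 4 or would leave the reading at the limit. Every compound shown also carries the same chloromethyl group, so its part in the toxicity remains open too, and a compound with a hydroxymethyl group or a longer chain in its place would be needed to address that.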